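Methyl in Place of Chloro at a Limit-Bound Series

The source may hold more compounds than are shown below. What is called first, only, known or untested is meant among the compounds shown, and "the series" means these compounds.

Compound 2 `Cc1ccc(S(=O)(=O)Oc2ccc3c(c2C)[C@H](Cn2cc(-c4ccc(Cl)cc4)nn2)[C@@]24CC(=O)[C@@](C)(CC[C@@H]32)C4)cc1` carries (4-methylphenyl)sulfonyl in place of hydrogen on an oxygen on an aromatic ring of compound 1 `Cc1c(O)ccc2c1[C@H](Cn1cc(-c3ccc(Cl)cc3)nn1)[C@@]13CC(=O)[C@@](C)(CC[C@@H]21)C3`. In a functional assay on A549 cells (Homo sapiens) for cytotoxicity, read by MTT assay, with a stated time of 4 days (a higher number here means a weaker inhibitor, a lower number a stronger inhibitor), compound 1 gives > 20000 nM, which is a limit of the assay rather than a number. In this assay compound 2 gives > 20000 nM, again a limit. The step that the two limits leave unreadable from compound 1 to compound 2 is therefore unreadable. A third compound with a different core, compound 3 `C=C1C[C@]23C[C@@]1(O)CC[C@@H]2c1cccc(C)c1[C@@H]3Cn1cc(-c2ccc(OC)cc2)nn1`, gives in this assay > 20000 nM, once more a limit. Among the measured compounds shown here, all three values sit at the limit of > 20000 nM in this assay, at which 3 of the 3 values shown sit, so compound 2 stands with the others at the edge of what the assay reports, with no measured step separating them.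

Compound 4 `Cc1ccc(-c2cn(C[C@H]3c4c(ccc(OS(=O)(=O)c5ccc(C)cc5)c4C)[C@@H]4CC[C@@]5(C)C[C@]43CC5=O)nn2)cc1` differs from compound 2 by methyl in place of chloro on an aromatic carbon. For the measured compounds named here, none of the measured steps touches this position, and the only step between measured compounds is itself unreadable, so there is no measured step of known size to carry over. The expected step to compound 4 in this assay is a step that the limit leaves unreadable from compound 2 to compound 4, meaning no change beyond the scatter. Compound 4 is estimated at 30000 nM, within a range from 10000 nM to 100000 nM, and is most likely to be reported again as a limit.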

Compound 4, half-maximal inhibitory concentration: > 20000 nM
Compound 4: no number, only a limit (the forecaster's own chance of this, stated with the estimate: 85%); the middle value is on the limit's open side.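

In this assay compound 4 gives > 20000 nM as a limit and not a number. Neither this result nor that of compound 2 gives a number, so no new step can be read between compound 2 and compound 4. The compounds shown leave open what change, if any, would bring a measurable value, since all stand at one edge: the limit of > 20000 nM in this assay, at which 4 of the 4 values shown sit.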